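A few compounds are considered here, and "the series" means these few. Any claim that something is new, unique, unknown or untested is made for them only; others in the source may bear on it.

Working notes on the stilbene-type series in an assay on HepG2 cells for activation of nuclear factor erythroid 2-related factor 2 (Homo sapiens), read by a luciferase reporter, with a stated time of 5 h; on this read-out lower numbers stand for an effect already at smaller amounts and higher numbers for an effect only at larger amounts of compound. Compound 1 `COc1ccc(/C=C/c2ccc(F)cc2)cc1` gives 4200 nM, compound 3 `COc1cccc(/C=C/c2ccc(F)cc2)c1` gives 6000 nM, and compound 2 `Cc1ccc(/C=C/c2ccc(F)cc2)cc1` gives 1300 nM. Within the data shown here, the one single-point step measured so far is a 3.2-fold lower number from compound 1 to compound 2 (0.51 log units; beyond the scatter). On these numbers compound 2 stands lowest of the three, with compound 1 nearest and compound 3 furthest, both steps beyond the scatter. Compound 4 `Cc1ccc(/C=C/c2ccc(F)c(F)c2)cc1` differs from compound 2 by fluoro in place of hydrogen on an aromatic carbon. Among the measured compounds shown here, no measured step in this set involves a fluoro entering or leaving, so nothing measured bears directly on this change; the only step seen concerns the methyl-for-methoxy exchange, not the fluorinated ring. The step from compound 2 to compound 4 in this assay is therefore expected to be within the scatter, no change at the digits printed from compound 2 to compound 4 (within the scatter). Compound 4 is estimated at 1300 nM, with a range from 500 nM to 3500 nM.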

Compound 4, half-maximal effective concentration: 2600 nM
Compound 4: middle estimate off by 2.0-fold (0.30 log units), on the low side, within the range that was stated.
By their numbers in this assay, from the lowest: compounds 2, 4, 1 and 3 (each within the scatter of the next, the first and the last beyond it).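

Fluoro in place of hydrogen on an aromatic carbon, ortho to a fluoro group, gives the first reading on this ring in this assay: a 2.0-fold higher number from compound 2 to compound 4 (0.30 log units; within the scatter). The earlier compounds shown here all kept this ring unchanged, and this one step shows that the position accepts a fluoro without a change beyond the scatter. No measurement at hand bears on the reason for this result. Open, going by these compounds, are whether an amine or a carboxylic acid at this position would step beyond the scatter, and whether this fluoro gives a similar step on the core of compound 1.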